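The source may report more compounds than this note shows. Statements on the series, on what has been measured and on what is new or still open speak of the compounds shown alone.

Working notes on the series.

Three compounds of this set have been run in a functional assay (spleen, spleen) for activation, with Mus musculus as the target; on this read-out lower numbers stand for an effect already at smaller amounts and higher numbers for an effect only at larger amounts of compound. Compound 1 `CCc1nc(N)c2nc(O)n(Cc3ccccc3)c2n1` gives 1 uM. Compound 2 `CCCNc1nc(N)c2nc(O)n(Cc3ccccc3)c2n1` gives 0.1 uM. Compound 3 `Nc1nc(S)nc2c1nc(O)n2Cc1ccccc1` gives 10 uM, which is the highest number of the three: the nearest is compound 1, the furthest compound 2, both beyond the scatter.

The measured steps all vary the same aromatic carbon of the shared core. There is a 10-fold lower number from compound 1 to compound 2 (1.00 log units; beyond the scatter), there is a 10-fold higher number from compound 1 to compound 3 (1.00 log units; beyond the scatter), and there is a 100-fold higher number from compound 2 to compound 3 (2.00 log units; beyond the scatter). Sulfanyl thus stands at the weak end of what has been tried there, and both replacements by a carbon- or nitrogen-linked chain lowered the number.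

Compound 4 `CCOc1nc(N)c2nc(O)n(Cc3ccccc3)c2n1` is the next point. The change is ethoxy in place of sulfanyl on an aromatic carbon. Ethoxy is an oxygen-linked chain, sized like ethyl and without the donor that sulfanyl carries; the two measured steps away from sulfanyl, a 10-fold higher number from compound 1 to compound 3 (1.00 log units; beyond the scatter) read in reverse and a 100-fold higher number from compound 2 to compound 3 (2.00 log units; beyond the scatter) read in reverse, both point toward a lower number in this assay, of modest to large size.

Compound 4 is therefore expected to show a 10-fold lower number from compound 3 to compound 4 (1.00 log units; beyond the scatter). The estimate for compound 4 in this assay is 1 uM, with a range from 0.2 uM to 5 uM.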

Compound 4, minimum effective concentration: 0.1 uM
The estimate for compound 4 lay 10-fold (1.00 log units) above the measured number, and the stated range ends above it.
By their numbers in this assay, from the lowest: compounds 2 and 4 (each within the scatter of the next); then compound 1; then compound 3.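

In this assay, going by these compounds alone, this aromatic carbon also tolerates an oxygen-linked chain: ethoxy in place of sulfanyl gives the step (a 100-fold lower number from compound 3 to compound 4 (2.00 log units; beyond the scatter)), and ethoxy in place of ethyl gives a further gain (a 10-fold lower number from compound 1 to compound 4 (1.00 log units; beyond the scatter)), so carbon-linked ethyl no longer stands as the only comparison of a small chain here. Ethoxy and propylamino cannot be told apart on this read-out (no change at the digits printed from compound 2 to compound 4 (within the scatter)), which shows that the low end of the series can be reached with either an oxygen or a nitrogen link. Ethoxy counts 0 hydrogen-bond donors, so a donor on this group is not required for a number this low, although nothing at hand accounts for the differences among these groups.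

Open, as far as these compounds go, is whether the low number holds for a shorter methoxy or a longer butoxy chain on this carbon, and whether ethylsulfanyl, which keeps the sulfur and carries a chain on it, stays close to compound 3 or moves toward compound 4. All of these comparisons also rest on a single read-out and on the shared core alone.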